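Replacing (trifluoromethyl)sulfanyl with trifluoromethyl in compound 3

This account rests on a few compounds, and the source may have more. Where it says the series, first, only, none or still open, it means among the compounds named here.

Measured so far in a functional assay on HCT-116 cells (Homo sapiens) for inhibition, read by MTT assay, with a stated time of 72 h; on this read-out higher numbers stand for weaker inhibition and lower numbers for stronger inhibition 
- Compound 1 `NS(=O)(=O)c1ccc2c(c1)C(=O)C(=O)N2Cc1cccc(C(F)(F)F)c1` gives 17700 nM 
- Compound 2 `NS(=O)(=O)c1ccc2c(c1)C(=O)C(=O)N2Cc1ccc(SC(F)(F)F)cc1` gives 14500 nM 

In this assay compound 2 stands at 14500 nM and compound 1 at 17700 nM and these two numbers lie within the usual scatter of each other, so neither compound can be ranked over the other.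

Still awaiting measurement is compound 3 `NS(=O)(=O)c1ccc2c(c1)C(=O)C(=O)N2Cc1ccc(C(F)(F)F)cc1` which differs from compound 2 in one place. It carries trifluoromethyl in place of (trifluoromethyl)sulfanyl on an aromatic carbon, para to a large group (trifluoromethyl in place of (trifluoromethyl)sulfanyl on an aromatic carbon).

Among the compounds with values here, no step between measured compounds differing in one place is available, so the data give no direct measure of this exchange. Within the data shown here, with compound 1 at 17700 nM and compound 2 at 14500 nM as the only guide, no change beyond the scatter is expected in this assay in either direction. The expected change is a 1.1-fold higher number from compound 2 to compound 3 (0.04 log units; within the scatter) and it is estimated to stay within the scatter. For compound 3 the expected value is 16000 nM with an estimated range from 8000 nM to 32000 nM.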

Compound 3, half-maximal inhibitory concentration: 30000 nM
Compound 3: the middle estimate sits 1.9-fold (0.27 log units) below what was measured; measured number inside the range.
By their numbers in this assay, from the lowest: compounds 2, 1 and 3 (each within the scatter of the next, the first and the last beyond it).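

In this assay, the exchange of (trifluoromethyl)sulfanyl for trifluoromethyl on an aromatic carbon, para to a large group, now has a direct measure: a 2.1-fold higher number from compound 2 to compound 3 (0.32 log units; beyond the scatter). Within the data shown here, the earlier compounds offered no pair differing in one place, so this modest step is the first sign that the group at this position can change the number beyond the scatter, with (trifluoromethyl)sulfanyl giving the stronger inhibition of the two. Nothing measured here bears on what lies behind this step.

A single pair leaves open whether this position follows any wider trend, and whether a trifluoromethoxy group, a chlorine atom, a nitrile or a plain hydrogen there would give a number nearer to that of compound 2 or to that of compound 3. It also leaves open whether the same exchange would give a step of similar size at the place held by the trifluoromethyl group of compound 1, or on a core carrying something other than the sulfonamide.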